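A Fluoro Added to the Chloro Analogue

The compounds below may be only part of what the source reports. "The series", "measured", "known", "first", "only" and "open" are said of these compounds alone.

Measured compounds:
compound 1 `O/N=C(/Nc1ccccc1)c1ccc2occc2c1`: 19000 nM
compound 2 `O/N=C(/Nc1cccc(Cl)c1)c1ccc2occc2c1`: 1500 nM

Within the data shown here, in an assay on tissue (HeLa cells) for inhibition of Indoleamine 2,3-dioxygenase 1 (Homo sapiens), read by spectrophotometry (on this read-out lower numbers stand for stronger inhibition and higher numbers for weaker inhibition), compound 1 gives 19000 nM and compound 2 gives 1500 nM, so compound 2 stands lowest of the two, the only step being a 13-fold lower number from compound 1 to compound 2 (1.10 log units; beyond the scatter). Compound 3 `O/N=C(/Nc1ccc(F)c(Cl)c1)c1ccc2occc2c1` differs from compound 2 by fluoro in place of hydrogen on an aromatic carbon. Among the measured compounds shown here, that measured step concerns chloro entering for hydrogen, not fluoro, so no step bears directly on this change. Compound 3 is therefore expected to sit close to compound 2, with an estimated step of a 1.5-fold lower number from compound 2 to compound 3 (0.18 log units; within the scatter) in this assay that stays near the scatter; the estimate for compound 3 is 1000 nM, within 300 nM to 4000 nM.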

Compound 3, half-maximal inhibitory concentration: 1800 nM
Compound 3: middle estimate off by 1.8-fold (0.26 log units), on the low side; measured number inside the range.
By their numbers in this assay, from the lowest: compounds 2 and 3 (each within the scatter of the next); then compound 1.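

In this assay fluoro in place of hydrogen on this aromatic carbon, ortho to a chloro group and para to a large group, gives a 1.2-fold higher number from compound 2 to compound 3 (0.08 log units; within the scatter) and so leaves the read-out unchanged within the scatter. This shows that the position accepts a fluoro group alongside the chloro group without a readable gain or loss. Nothing available explains this outcome.

The compounds shown leave open whether a larger group at this position, such as methoxy or an amine, would do the same. They also leave open how fluoro behaves here without the chloro group.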